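Para methoxy for methyl across two amide cores

A few compounds are considered here, and "the series" means these few. Any claim that something is new, unique, unknown or untested is made for them only; others in the source may bear on it.

Compound 1 `Cc1ccc(-n2cc(NC(=O)c3cccc(NS(=O)(=O)c4ccccc4)c3)cn2)cc1` and compound 2 `COc1ccc(-n2cc(NC(=O)c3cccc(NS(=O)(=O)c4ccccc4)c3)cn2)cc1` share one core; in a functional assay on A549 cells (Homo sapiens) for inhibition, read by MTT assay, with a stated time of 48 h (a higher number here means a weaker inhibitor, a lower number a stronger inhibitor), compound 1 gives 18900 nM and compound 2 gives 76800 nM. The change between them, (methoxy in place of methyl on an aromatic carbon), moves the read-out as a 4.1-fold higher number from compound 1 to compound 2 (0.61 log units; beyond the scatter). Compound 3 `Cc1ccc(-n2cc(NC(=O)c3ccc(NS(=O)(=O)c4ccccc4)cc3)cn2)cc1` carries the other core, and in this assay compound 3 gives 54700 nM; the difference between the two cores is not broken down here. Compound 4 `COc1ccc(-n2cc(NC(=O)c3ccc(NS(=O)(=O)c4ccccc4)cc3)cn2)cc1` has not yet been measured in this assay. Compound 4 relates to compound 3 by methoxy in place of methyl on an aromatic carbon, the same change as from compound 1 to compound 2, at the same place, para to a large group on a six-membered aromatic ring of carbon only. For the measured compounds named here, because the earlier step was a 4.1-fold higher number from compound 1 to compound 2 (0.61 log units; beyond the scatter), the step from compound 3 to compound 4 is expected to be of similar size, a 2.9-fold higher number from compound 3 to compound 4 (0.47 log units; beyond the scatter), though only one prior example supports this and the second core may respond differently. Compound 4 is therefore estimated at 160000 nM in this assay, with a plausible span from 60000 nM to 400000 nM.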

Compound 4, half-maximal inhibitory concentration: 85800 nM
Compound 4: the middle estimate sits 1.9-fold (0.27 log units) above what was measured, and the stated range covers the measured number.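

In this assay, replacing 4-methylphenyl with 4-methoxyphenyl on the second core gives a 1.6-fold higher number from compound 3 to compound 4 (0.20 log units; within the scatter), a step that cannot be told apart from repeat variation. Set beside the step on the first core, the two do not separate: the same change on two cores in this assay, a 4.1-fold higher number (0.61 log units; beyond the scatter) from compound 1 to compound 2 and a 1.6-fold higher number (0.20 log units; within the scatter) from compound 3 to compound 4, 2.6-fold (0.41 log units) apart, within the scatter of two such steps. This gives no support for a core-dependent response, but it does not establish a common step size either: the evidence is a single pair of steps, only one of which lies beyond the scatter, so the change cannot yet be said to carry over reliably from one core to the other.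

Still open, as far as these compounds go, is whether other groups at this place on an aromatic carbon, such as chlorine, trifluoromethyl or an amine, would give matching steps on the two cores. Also open, from the compounds shown here alone, is how a carboxylic acid or a longer chain in place of the methyl would behave on either core.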